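The compounds below may be only part of what the source reports. "The series", "measured", "known", "first", "only" and "open" are said of these compounds alone.

Measured in a functional assay on the whole organism with Rattus norvegicus as the target; on this read-out higher numbers stand for an effect only at larger amounts of compound and lower numbers for an effect already at smaller amounts:
- compound 1 `CCOC(=O)C(=O)Nc1cccc(OC)c1C#N`: 55.5 mg/kg
- compound 2 `CCOC(=O)C(=O)Nc1cccc(N)c1C#N`: 0.07 mg/kg
- compound 3 `CCOC(=O)C(=O)Nc1cccc(C)c1C#N`: 4.6 mg/kg

These three compounds differ only in one group on an aromatic carbon of the shared core. Compound 3 has the second highest of the three numbers, and it stands apart from both neighbours: the methoxy compound gives way to it in a 12-fold lower number from compound 1 to compound 3 (1.08 log units; beyond the scatter), and the amino compound gives way to it in a 66-fold higher number from compound 2 to compound 3 (1.82 log units; beyond the scatter).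

The next compound, compound 4 `CCOC(=O)C(=O)Nc1cccc(OC(C)C)c1C#N`, carries isopropoxy in place of methyl on an aromatic carbon. Among the compounds with values here, no measured step makes exactly this swap. The closest guide is a 12-fold lower number from compound 1 to compound 3 (1.08 log units; beyond the scatter), which replaces methoxy with methyl, the reverse kind of change, since methoxy, like isopropoxy, is attached through oxygen. Going back from methyl to an oxygen-linked group therefore points to a higher number in this assay. The size is uncertain, as isopropoxy itself has not been tested, and a 790-fold lower number from compound 1 to compound 2 (2.90 log units; beyond the scatter) shows how far one swap at this carbon can move the number. An expected change of a 5.4-fold higher number from compound 3 to compound 4 (0.74 log units; beyond the scatter) is a cautious estimate, smaller than the methoxy step. For compound 4 the estimated value is 25 mg/kg, with an expected range from 4 mg/kg to 150 mg/kg.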

Compound 4, dose for half-maximal effect: 1 mg/kg
Estimate against measurement, compound 4: 25-fold (1.40 log units) above; the whole stated range lies above it.
By their numbers in this assay, from the lowest: compound 2; then compound 4; then compound 3; then compound 1.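

Isopropoxy shows that being attached through oxygen does not by itself give a high number at this carbon, ortho to a cyano group: in this assay, exchanging the methyl on that oxygen for isopropyl gives a 56-fold lower number from compound 1 to compound 4 (1.74 log units; beyond the scatter), a large shift with the linking oxygen unchanged. The two oxygen-linked groups also fall on opposite sides of methyl, since the change from methyl to isopropoxy gives a 4.6-fold lower number from compound 3 to compound 4 (0.66 log units; beyond the scatter), whereas the methoxy compound has the highest number of the four, so the earlier methoxy-to-methyl step did not reveal a general effect of oxygen-linked groups. Even so, isopropoxy does not reach the amino compound, as a 14-fold higher number from compound 2 to compound 4 (1.15 log units; beyond the scatter) shows, and nothing available here explains why these groups rank as they do.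

The compounds shown leave open how the number changes along the series of oxygen-linked groups, for instance whether ethoxy would fall between methoxy and isopropoxy or whether a longer chain such as butoxy would continue the trend. They also leave open whether the very low number of the amino compound would survive with a methylamino or dimethylamino group at this carbon.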